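The compounds below may be only part of what the source reports. "The series", "measured", "known", "first", "only" and "open" are said of these compounds alone.

Going by the values given here, in a physicochemical assay for solubility, with a stated time of 24 h, tested at 30 mg/mL (a higher number here means a more soluble compound, a lower number a less soluble compound), compound 1, `C[C@H](Nc1c(NCCCCCC(=O)NO)c(=O)c1=O)c1ccccc1`, gives 28000000 nM, the lowest of the two numbers measured so far. Its closest and only comparison is compound 2, `CC[C@H](Nc1c(NCCCCCC(=O)NO)c(=O)c1=O)c1ccccc1`, which gives 57000000 nM. The next compound to be measured is compound 3, `Cc1ccccc1[C@H](C)Nc1c(NCCCCCC(=O)NO)c(=O)c1=O`, which keeps the shared core and the hydroxamic acid chain of compound 1 and changes only the aromatic ring, from phenyl to 2-methylphenyl. The counted difference is methyl in place of hydrogen on an aromatic carbon. In words, this is methyl in place of hydrogen on an aromatic carbon.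

Among the compounds with values here, only one measured step bears on this change: a 2.0-fold higher number from compound 1 to compound 2 (0.31 log units; beyond the scatter). That modest step also adds a methyl in place of hydrogen, but on a saturated chain carbon rather than on an aromatic carbon, so it is only a loose guide. A single step cannot show how a methyl on the ring will behave, so only a small upward move is expected, a 1.3-fold higher number from compound 1 to compound 3 (0.10 log units; within the scatter). For compound 3 the estimated value in this assay is 35000000 nM, with an expected range from 13000000 nM to 90000000 nM.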

Compound 3, solubility: 47000000 nM
Beside the measured number, compound 3's estimate is 1.3-fold (0.13 log units) below it; low and high end bracket the measured number.
By their numbers in this assay, from the lowest: compounds 1, 3 and 2 (each within the scatter of the next, the first and the last beyond it).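

Going by these compounds alone, compound 3 is the first compound here changed on the aromatic ring itself, with a methyl on an aromatic carbon, ortho to a large group, in place of a hydrogen. In this assay, the change from phenyl to 2-methylphenyl gives a 1.7-fold higher number from compound 1 to compound 3 (0.22 log units; within the scatter), so this single methyl cannot be told apart from the ordinary spread of repeated measurements, whereas the earlier methyl on the saturated chain carbon gave a 2.0-fold higher number from compound 1 to compound 2 (0.31 log units; beyond the scatter). The two methyl additions therefore read differently against the scatter, although each rests on one step only, and nothing shown gives a reason for this result.

The compounds shown leave open whether a different group at this same ring carbon, such as a methoxy group, a chlorine atom or an amine, would produce a step beyond the scatter. On these data alone, it is also open whether a methyl on another carbon of the ring would behave as this one does, and whether the ring methyl and the added chain methyl would combine in one compound.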